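Swapping Methyl for Chloro on a Shared Core

The source may report more compounds than this note shows. Statements on the series, on what has been measured and on what is new or still open speak of the compounds shown alone.

Compound 1 `Cc1ccc2c(=O)c(CSC(=S)N3CCCCC3)coc2c1` gives 5100 nM in a functional assay on LM7 cells (Homo sapiens) for antiproliferative activity, read by MTT assay, with a stated time of 72 h; on this read-out higher numbers stand for weaker inhibition and lower numbers for stronger inhibition. Compound 2 `Cc1ccc2c(=O)c(CSC(=S)N(C(C)C)C(C)C)coc2c1` gives 6300 nM in this assay. Compound 3 `Cc1ccc2c(=O)c(CSC(=S)N3CCOCC3)coc2c1` gives 14300 nM in this assay.

Among these three numbers compound 2 stands second highest: its nearest neighbour is compound 1, a 1.2-fold higher number from compound 1 to compound 2 (0.09 log units; within the scatter), and its furthest is compound 3, a 2.3-fold higher number from compound 2 to compound 3 (0.36 log units; beyond the scatter); the remaining step is a 2.8-fold higher number from compound 1 to compound 3 (0.45 log units; beyond the scatter). Compound 4 `CC(C)N(C(=S)SCc1coc2cc(Cl)ccc2c1=O)C(C)C` differs from compound 2 by chloro in place of methyl on an aromatic carbon. Every measured step concerns the group on the thiocarbonyl carbon, so none bears directly on a change at the aromatic ring. With no guidance from the measured steps, the account expects no change beyond the scatter, no change at the digits printed from compound 2 to compound 4 (within the scatter). The estimate for compound 4 in this assay is 6300 nM, with a range from 2500 nM to 16000 nM.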

Compound 4, half-maximal inhibitory concentration: > 25000 nM
Compound 4 was reported as a limit; the forecaster's own chance of this, stated with the estimate: 5%; middle value at least 3.9-fold (0.59 log units) away from the limit.
By their numbers in this assay, from the lowest: compounds 1 and 2 (each within the scatter of the next); then compound 3. At a limit, above all of these: compound 4.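

Chloro in place of methyl on an aromatic carbon gives, in this assay, an at least 3.9-fold higher number from compound 2 to compound 4 (0.59 log units; beyond the scatter). Among these compounds, the earlier compounds varied only the group on the thiocarbonyl carbon, so this is the first sign that the aromatic position also affects this read-out. Compound 4 stands at a limit and not at a number: the limit of > 25000 nM in this assay, at which 1 of the 4 values shown sits.

As far as these compounds go, how far past that limit compound 4 lies stays open, as does whether the step would recur with piperidin-1-yl or morpholin-4-yl on the thiocarbonyl carbon. Also open, from the compounds shown here alone, is how fluoro, methoxy or an amine on this aromatic carbon would read.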